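The compounds below may be only part of what the source reports. "The series", "measured", "known", "first", "only" and "open" are said of these compounds alone.

Measured so far:
compound 1 `COc1ccc2c(c1)CC(c1nc3c(N(C)CCN(C)C)cc(-c4cn[nH]c4)cc3c(=O)[nH]1)CO2` — 21 nM in an assay on isolated protein for inhibition of Rho-associated protein kinase 2 (Homo sapiens), read by HTRF; on this read-out lower numbers stand for stronger inhibition and higher numbers for weaker inhibition
compound 2 `Cc1ccc2c(c1)CC(c1nc3ccc(-c4cn[nH]c4)cc3c(=O)[nH]1)CO2` — 6 nM in this assay

In this assay compound 2 gives the lower of the two numbers; compound 1 gives a number that is higher by more than the usual scatter, but the two structures differ in several places, so nothing can be read from that pair about any single change.

Compound 3 `COCCNC(=O)c1ccc2c(c1)CC(c1nc3ccc(-c4cn[nH]c4)cc3c(=O)[nH]1)CO2` has not yet been measured. It differs from compound 2 in one place: (2-methoxyethyl)carbamoyl in place of methyl on an aromatic carbon. Among the measured compounds shown here, no step between measured compounds covers this kind of change, so the expectation rests on compound 2 alone. For the measured compounds named here, with no comparable step in hand, the expected step from compound 2 to compound 3 is a modest loss of potency, at or somewhat beyond the scatter, with a wide band around it; the estimated step is a 2.5-fold higher number from compound 2 to compound 3 (0.40 log units; beyond the scatter). For compound 3 the expected value in this assay is 15 nM, with a range from 4 nM to 60 nM.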

Compound 3, half-maximal inhibitory concentration: < 1 nM
Compound 3: only a limit was reported; the forecaster's own chance of this, stated with the estimate: 2%; middle value at least 15-fold (1.17 log units) from the limit.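

The aromatic carbon that is meta to a fused ring and para to a fused ring accepts much more than methyl: in this assay, (2-methoxyethyl)carbamoyl in place of methyl gives an at least 6.0-fold lower number from compound 2 to compound 3 (0.77 log units; beyond the scatter). The earlier compounds shown here gave no reading at this position, and this step shows that a chain of 7 heavy atoms, with 1 hydrogen-bond donor and 2 hydrogen-bond acceptors, can stand here with a gain in potency beyond the scatter rather than a loss. The figure for compound 3 is a limit and not a number, so the step has a floor but no known full size: the limit of < 1 nM in this assay, at which 1 of the 3 values shown sits.

Among the compounds shown here, the single step does not separate the contribution of the carbonyl and amide hydrogen from that of the methoxyethyl tail; a simple unsubstituted carboxamide, a carboxylic acid or a longer chain ending in an amine at the same carbon would begin to divide them. Going by these compounds, whether the gain carries over to a core bearing other changes, such as that of compound 1, also stays open, since it rests on one pair of compounds.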